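O-Methylation of an Oxime: Expected Maximal Response

The source may hold more compounds than are shown below. What is called first, only, known or untested is meant among the compounds shown, and "the series" means these compounds.

compound 1 `Cc1ccccc1/C(CCN1CCN(c2ccccn2)CC1)=N\O`: 72%
compound 2 `O/N=C(/CCN1CCN(c2ccccn2)CC1)c1cc(F)cc(F)c1`: 70%

In a functional assay on HEK293 cells with D(4) dopamine receptor (Homo sapiens) as the target, read by FLIPR (on this read-out higher numbers stand for larger maximal responses and lower numbers for smaller maximal responses), compound 1 shows the higher of the two numbers, with compound 2 nearest at a number 2 percentage points lower from compound 1 to compound 2 (within the scatter). Compound 3 `CO/N=C(/CCN1CCN(c2ccccn2)CC1)c1ccccc1C` differs from compound 1 by methyl in place of hydrogen on an oxygen. For the measured compounds named here, no measured step touches this oxygen; the single available step alters a different part of the molecule and stays within the scatter, so it gives no direct guidance. The step from compound 1 to compound 3 is therefore expected to be a number 4 percentage points lower from compound 1 to compound 3 (within the scatter), nothing beyond the scatter. Compound 3 is estimated to give 68%, between 50% and 85%.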

Compound 3, largest response reached (reported as efficacy), in percent of the reference or control that the assay uses: 72%
Compound 3: middle estimate off by 4 percentage points, on the low side, within the range that was stated.
By their numbers in this assay, from the lowest: compounds 2, 1 and 3 (each within the scatter of the next).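

In this assay, methyl in place of hydrogen on an oxygen whose other neighbours are double-bonded nitrogen gives no change at the digits printed from compound 1 to compound 3 (within the scatter) in this pair. The earlier step changed only another part of the molecule, whereas this one shows that, with the core of compound 1, the maximal response holds when hydroxy becomes methoxy. Nothing available offers an explanation for this result. As far as these compounds go, whether an ethyl or benzyl group on this oxygen would leave the maximal response in the same place remains open. So does whether methoxy would do so alongside the 3,5-difluorophenyl group of compound 2.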